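Methyl to Trifluoromethyl on Sulfur: an Expected Cytotoxicity Step

The source may report more compounds than this note shows. Statements on the series, on what has been measured and on what is new or still open speak of the compounds shown alone.

Compound 1, `CSc1ccc(NC(=O)Nc2cc(C)nc3ccccc23)cc1`, gives 16000 nM in an ADME assay on HepG2 cells (Homo sapiens) for cytotoxicity, with a stated time of 72 h; a lower number here means that less compound is needed, a higher number that more compound is needed for the effect.
Compound 2, `Cc1cc(NC(=O)Nc2ccccc2C(C)(C)C)c2ccccc2n1`, reaches only a limit of this assay, > 25000 nM.
Compound 3, `COc1ccc(NC(=O)Nc2cc(C)nc3ccccc23)cc1F`, likewise reaches only a limit of this assay, > 25000 nM.

Among the three measured compounds, compound 1 stands alone as the only one with a number in this assay; the other two sit at the limit of > 25000 nM in this assay, at which 2 of the 3 values shown sit, so no step between measured compounds can be drawn, and nothing shows whether compound 2 or compound 3 differs from compound 1 beyond the scatter.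

The unmeasured compound 4, `Cc1cc(NC(=O)Nc2ccc(SC(F)(F)F)cc2)c2ccccc2n1`, differs from compound 1 in one place: trifluoromethyl in place of methyl on a sulfur. Going by the values given here, no measured pair shows what such a change does in this assay, so the expectation rests on compound 1 alone, with a small step in either direction being as likely as none. Compound 4 is therefore expected to give about 13000 nM, within a range from 5000 nM to 25000 nM. This estimate implies a 1.2-fold lower number from compound 1 to compound 4 (0.09 log units; within the scatter), a step expected to fall within the usual scatter, with a fair chance that the assay again reports only a limit.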

Compound 4, half-maximal effective concentration: 20000 nM
The estimate for compound 4 lay 1.5-fold (0.19 log units) below the measured number; measured number inside the range.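

With compound 4, the sulfur gains its first readable step in this assay: trifluoromethyl in place of methyl gives a 1.3-fold higher number from compound 1 to compound 4 (0.10 log units; within the scatter). The earlier compounds shown here could not show this, as compound 1 alone carried a number and no pair differing in one place existed. Here, on a sulfur whose other neighbour is an aromatic carbon, the exchange leaves compound 1 and compound 4 within the scatter of each other, and both give a number rather than a limit.

As far as these compounds go, whether the same holds for other groups on this sulfur, such as an ethyl chain or an amine, remains open, since this single step speaks only for trifluoromethyl. Steps to compound 2 and compound 3 cannot be read: the limit of > 25000 nM in this assay, at which 2 of the 4 values shown sit.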